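The source may report more compounds than this note shows. Statements on the series, on what has been measured and on what is new or still open speak of the compounds shown alone.

Values so far in an ADME assay on BCBL1 cells (Homo sapiens) for cytotoxicity, with a stated time of 7 days (on this read-out lower numbers stand for higher toxicity in this test and higher numbers for lower toxicity in this test), are:
- compound 1 `CNc1nc(N)nc2c1ncn2/C=C1/CC1(CO)CO` gives 67000 nM
- compound 2 `CSc1nc(N)nc2c1ncn2/C=C1/CC1(CO)CO` gives > 20000 nM as a limit

Compound 2 has no number and stands only at this limit. Compound 3 `CCCCCCSc1nc(N)nc2c1ncn2/C=C1/CC1(CO)CO` differs from compound 2 by pentyl in place of hydrogen on a saturated chain carbon bound to a sulfur and carries pentyl in place of hydrogen on a saturated chain carbon bound to a sulfur, turning methylsulfanyl into hexylsulfanyl. Within the data shown here, the only measured step is a step that the limit leaves unreadable from compound 1 to compound 2 and offers no size to carry over. The series also shows the limit of > 20000 nM in this assay, at which 1 of the 2 values shown sits, and a further limit for compound 3 is therefore a real possibility. The expected step is a step that the limit leaves unreadable from compound 2 to compound 3 and both its size and direction are only loosely estimated. Compound 3 is expected at 30000 nM with an estimated range from 8000 nM to 100000 nM in this series.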

Compound 3, half-maximal cytotoxic concentration: > 20000 nM
Compound 3: no number, only a limit; the forecaster's own chance of this, stated with the estimate: 45%; the middle value does not contradict the limit.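

No step among compound 1, compound 2 and compound 3 can be read, with the series resting largely on one limit: the limit of > 20000 nM in this assay, at which 2 of the 3 values shown sit.

Still open, as far as these compounds go, is what number compound 2 and compound 3 would give in this assay, and so whether methylsulfanyl and hexylsulfanyl differ on this read-out at all.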